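A few compounds are considered here, and "the series" means these few. Any claim that something is new, unique, unknown or untested is made for them only; others in the source may bear on it.

In a functional assay on U-937 cells (Homo sapiens) for inhibition, read by MTT assay, with a stated time of 72 h (a higher number here means a weaker inhibitor, a lower number a stronger inhibitor), compound 3 `Nc1ccccc1NC(=O)c1ccc(CNCc2nc(-c3cccs3)no2)cc1` gives 5960 nM, the highest of the three numbers, while compound 1 `Nc1ccccc1NC(=O)c1ccc(CNCc2nc(-c3ccc(C(F)(F)F)cc3)no2)cc1` gives 2580 nM and compound 2 `Nc1ccccc1NC(=O)c1ccc(CNCc2nc(-c3ccc(F)cc3)no2)cc1` gives 1250 nM. Compound 4 `O=C(NO)c1ccc(CNCc2nc(-c3cccs3)no2)cc1` differs from compound 3 by hydroxy in place of 2-aminophenyl on an amide-type nitrogen, with hydroxy in place of 2-aminophenyl on an amide-type nitrogen. For the measured compounds named here, no measured step touches this nitrogen, so the direction rests on judgement alone. The steps at the aromatic carbon, a 2.1-fold lower number from compound 1 to compound 2 (0.31 log units; beyond the scatter), a 2.3-fold higher number from compound 1 to compound 3 (0.36 log units; beyond the scatter) and a 4.8-fold higher number from compound 2 to compound 3 (0.68 log units; beyond the scatter), offer only a scale of modest size. A modest move toward a lower number is therefore expected, an estimated 4.0-fold lower number from compound 3 to compound 4 (0.60 log units; beyond the scatter). For compound 4 the estimated value is 1500 nM, with an expected range from 300 nM to 6000 nM.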

Compound 4, half-maximal inhibitory concentration: 10700 nM
Compound 4: the middle estimate sits 7.1-fold (0.85 log units) below what was measured, outside the stated range (above it).
By their numbers in this assay, from the lowest: compound 2; then compound 1; then compounds 3 and 4 (each within the scatter of the next).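

In this assay, hydroxy in place of 2-aminophenyl on the amide-type nitrogen gives a 1.8-fold higher number from compound 3 to compound 4 (0.25 log units; within the scatter). For the compounds shown here, this is the first reading at this nitrogen, since the earlier steps changed only the aromatic carbon, and it shows that with thiophen-2-yl held fixed, the two groups cannot be told apart here, although one has 7 heavy atoms and the other 1. The compounds shown leave open whether hydroxy and 2-aminophenyl would also match with 4-fluorophenyl on the aromatic carbon, and how a methoxy group or plain phenyl on this nitrogen would compare. No supporting data bear on this result.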